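Swapping 4-nitrophenyl for 2-fluorophenyl on the shared core

The compounds below may be only part of what the source reports. "The series", "measured", "known", "first", "only" and "open" are said of these compounds alone.

In a functional assay on DU-145 cells (Homo sapiens) for cytotoxicity, read by sulforhodamine B assay, with a stated time of 48 h (on this read-out higher numbers stand for weaker inhibition and lower numbers for stronger inhibition), compound 1 (`C[C@H]1CC[C@@H]2[C@@H](OC(=O)[C@]23CC(c2c(Cl)cccc2Cl)=NO3)[C@]2(C)C(=O)C=C[C@@]12O`) gives 38000 nM and compound 2 (`C[C@H]1CC[C@@H]2[C@@H](OC(=O)[C@]23CC(c2ccccc2Br)=NO3)[C@]2(C)C(=O)C=C[C@@]12O`) gives 18000 nM while compound 3 (`C[C@H]1CC[C@@H]2[C@@H](OC(=O)[C@]23CC(c2ccc([N+](=O)[O-])cc2)=NO3)[C@]2(C)C(=O)C=C[C@@]12O`) gives 7000 nM as the lowest of the three numbers. Compound 4 (`C[C@H]1CC[C@@H]2[C@@H](OC(=O)[C@]23CC(c2ccccc2F)=NO3)[C@]2(C)C(=O)C=C[C@@]12O`) awaits measurement and carries 2-fluorophenyl in place of 4-nitrophenyl on a carbon with a double bond to nitrogen. Two modest measured steps arrive at 4-nitrophenyl: a 2.6-fold lower number from compound 2 to compound 3 (0.41 log units; beyond the scatter) from 2-bromophenyl and a 5.4-fold lower number from compound 1 to compound 3 (0.73 log units; beyond the scatter) from 2,6-dichlorophenyl. Of the measured groups, the 2-bromophenyl of compound 2 (18000 nM) is the nearest match, so a modest move to a higher number is expected in this assay on leaving 4-nitrophenyl. The expected change is a 2.1-fold higher number from compound 3 to compound 4 (0.33 log units; beyond the scatter) in size. Compound 4 is estimated at 15000 nM with an expected range of 6000 nM to 40000 nM around that figure.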

Compound 4, half-maximal inhibitory concentration: 24000 nM
Compound 4: the middle estimate sits 1.6-fold (0.20 log units) below what was measured; measured number inside the range.
By their numbers in this assay, from the lowest: compound 3; then compounds 2, 4 and 1 (each within the scatter of the next, the first and the last beyond it).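

In this assay, replacing 4-nitrophenyl with 2-fluorophenyl at this carbon gives a clear step (a 3.4-fold higher number from compound 3 to compound 4 (0.54 log units; beyond the scatter)), so compound 3 remains apart from all three halogen-bearing compounds. Fluoro in place of bromo makes no difference beyond the scatter (a 1.3-fold higher number from compound 2 to compound 4 (0.12 log units; within the scatter)), and neither does the change from 2,6-dichlorophenyl (a 1.6-fold lower number from compound 1 to compound 4 (0.20 log units; within the scatter)). No measurement here explains these results.

As far as these compounds go, it remains open whether the number of compound 3 is specific to the nitro group. An amine or a carboxylic acid on the phenyl ring also remains untested among the compounds shown.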